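This account rests on a few compounds, and the source may have more. Where it says the series, first, only, none or still open, it means among the compounds named here.

Three compounds sharing one core have been measured so far in a functional assay on HepG2 cells (Homo sapiens) for inhibition, read by MTT assay, with a stated time of 24 h (a lower number here means a stronger inhibitor of growth, a higher number a weaker inhibitor of growth), with these results:

compound 1 `COc1cccc(C(=O)n2c(-c3cn(C)c4ccc(OC)cc34)nc3ccccc32)c1` gives 11700 nM
compound 2 `COc1ccc2c(c1)c(-c1nc3ccccc3n1C(=O)c1ccccc1Br)cn2C` gives 54200 nM
compound 3 `COc1ccc2c(c1)c(-c1nc3ccccc3n1C(=O)c1cccc(Br)c1)cn2C` gives 51300 nM

Two of these compounds share the high end of the numbers and cannot be told apart (the step is a 1.1-fold lower number from compound 2 to compound 3 (0.02 log units; within the scatter)). Compound 1 lies clearly lower (the step is a 4.6-fold higher number from compound 1 to compound 2 (0.67 log units; beyond the scatter)).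

The open question is compound 4 `Cn1cc(-c2nc3ccccc3n2C(=O)c2ccccc2Br)c2cc(Br)ccc21`, which keeps the 2-bromophenyl group on the carbonyl, as in compound 2, but changes the core. The change is bromo in place of methoxy on an aromatic carbon (bromo in place of methoxy on an aromatic carbon of a six-membered aromatic ring of carbon only).

Among the measured compounds shown here, only one measured step makes this same swap, and it does so elsewhere in the molecule, on the phenyl group attached to the carbonyl. That step, a 4.4-fold higher number from compound 1 to compound 3 (0.64 log units; beyond the scatter), was a modest rise. For the measured compounds named here, no measured pair makes the swap on the core itself, so this size can only be borrowed with caution. In this assay a modest rise is therefore expected, with the estimated size given by a 1.8-fold higher number from compound 2 to compound 4 (0.24 log units; within the scatter) (weaker growth inhibition, not stronger). Compound 4 is expected at 95000 nM (estimated range 40000 nM to 220000 nM).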

Compound 4, concentration for 50% growth inhibition: 72100 nM
The estimate for compound 4 lay 1.3-fold (0.12 log units) above the measured number; the range from low to high includes it.
By their numbers in this assay, from the lowest: compound 1; then compounds 3, 2 and 4 (each within the scatter of the next).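

In this assay, placing bromo instead of methoxy on the shared core gives a 1.3-fold higher number from compound 2 to compound 4 (0.12 log units; within the scatter), so at this place on the core the swap cannot be told apart from no change at all. The earlier compounds shown here showed this swap only on the phenyl group attached to the carbonyl, where it was a clear step, and the pair of results now shows that the same exchange of groups need not have the same size at different places in these molecules: the same change on two cores in this assay, a 4.4-fold higher number (0.64 log units; beyond the scatter) from compound 1 to compound 3 and a 1.3-fold higher number (0.12 log units; within the scatter) from compound 2 to compound 4, 3.3-fold (0.52 log units) apart, beyond the scatter of two such steps With the 2-bromophenyl group on the carbonyl, the methoxy on the core can thus be replaced by bromo without a step beyond the scatter, although this rests on a single pair of compounds.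

On these data alone, whether the swap on the core stays this small when the carbonyl carries the 3-methoxyphenyl group of compound 1 remains open. Also open, as far as these compounds go, is how this place on the core responds to a group of a different kind, such as an amine, a carboxylic acid or a longer chain.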